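The compounds below may be only part of what the source reports. "The series", "measured", "known", "first", "only" and "open" are said of these compounds alone.

For the measured compounds named here, compound 2 `OCC#CCSc1cnc2ccccc2c1SCC#CCBr` stands at the higher end of the two numbers measured so far: in a functional assay on P388 cells (Mus musculus) for cytotoxicity, read by MTT assay, with a stated time of 72 h (a lower number here means a stronger inhibitor, a higher number a weaker inhibitor), compound 2 gives 43.2 ug/mL, whereas compound 1 `OCC#CCSc1cnc2ccccc2c1[Se]CC#CCBr` gives 1.6 ug/mL. Going by the values given here, the single measured step between them, a 27-fold higher number from compound 1 to compound 2 (1.43 log units; beyond the scatter), exchanged a selenium-bearing group for a sulfur-bearing one on the same aromatic carbon. Compound 3 `OCC#CCSc1cnc2ccccc2c1[Se]CC#CCO` has not yet been tested in this assay. It differs from compound 2 in one place: a group of 6 heavy atoms (4 carbon, 1 oxygen, 1 selenium; no ring) in place of a group of 6 heavy atoms (4 carbon, 1 sulfur, 1 bromine; no ring), on an aromatic carbon. One part of this change returns selenium in place of sulfur. That part runs opposite to the measured step, which was large and beyond the scatter. The other part, bromine giving way to oxygen with its hydrogen-bond donor, has no measured counterpart among these compounds, so its contribution is unknown. For compound 3 one therefore expects a step of an 11-fold lower number from compound 2 to compound 3 (1.03 log units; beyond the scatter) toward a lower number, taken as somewhat smaller than a complete reversal. Going by these compounds, the oxygen-for-bromine portion is untested. Compound 3 is estimated at 4 ug/mL, with a range from 1.2 ug/mL to 15 ug/mL.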

Compound 3, concentration for 50% inhibition: 4.1 ug/mL
Estimate against measurement, compound 3: 1.0-fold (0.01 log units) below; the measured number falls inside the stated range.
By their numbers in this assay, from the lowest: compound 1; then compound 3; then compound 2.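

The new value separates the two parts of the change at this aromatic carbon. Within the selenium-bearing pair, hydroxy in place of bromo on the saturated chain carbon bound to a triple-bonded carbon gives a 2.6-fold higher number from compound 1 to compound 3 (0.41 log units; beyond the scatter) in this assay, so the bromo end is not needed for a low number, though the exchange does cost something beyond the scatter. The larger 11-fold lower number from compound 2 to compound 3 (1.02 log units; beyond the scatter) therefore comes with the return of selenium in place of sulfur, even though the hydroxy end enters at the same time, and the earlier selenium-to-sulfur step alone could not show that selenium keeps the number low with either chain end.

Going by these compounds, whether sulfur and selenium differ by as much when the chain ends in hydroxy stays open, as does the effect of an amine, a methoxy group or a chloro atom at that chain end, or of a longer chain. No measurement at hand explains why these exchanges move the number as they do.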